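The source may hold more compounds than are shown below. What is called first, only, known or untested is meant among the compounds shown, and "the series" means these compounds.

Measured compounds in an ADME assay on PBMC cells (Homo sapiens) for cytotoxicity; on this read-out lower numbers stand for higher toxicity in this test and higher numbers for lower toxicity in this test:

- compound 1 `Cc1cc(Cl)nc(C)c1C(=O)NCC[C@@H](C)N1CCC(N(Cc2ccsc2)C(=O)CC2CCOCC2)CC1` — recorded as a limit of the assay, > 35600 nM.
- compound 2 `Cc1cc(Cl)nc(C)c1C(=O)NCC[C@@H](C)N1CCC(N(Cc2ccsc2)C(=O)Nc2cccnc2)CC1` — recorded as a limit of the assay, > 32300 nM.
- compound 3 `Cc1cc(C#N)nc(C)c1C(=O)NCC[C@@H](C)N1CCC(N(Cc2ccsc2)C(=O)CC2CCOCC2)CC1` — recorded as a limit of the assay, > 36200 nM.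

None of the three gives a number; each value is a limit only. Compound 2 therefore sits at a limit, with the two other values also limits. The step from compound 1 to compound 2 in this assay reads a step that the two limits leave unreadable from compound 1 to compound 2, and the step from compound 1 to compound 3 reads a step that the two limits leave unreadable from compound 1 to compound 3; neither limit pair can be turned into a size. The evidence is the limit of > 32300 nM in this assay, at which 1 of the 3 values shown sits, the limit of > 35600 nM in this assay, at which 1 of the 3 values shown sits, and (the limit of > 36200 nM in this assay, at which 1 of the 3 values shown sits).

Compound 4 `CNC(=O)N(Cc1ccsc1)C1CCN([C@H](C)CCNC(=O)c2c(C)cc(Cl)nc2C)CC1` differs from compound 2 by methyl in place of pyridin-3-yl on an amide-type nitrogen. This is a change at the same carbonyl-bearing position as the step from compound 1 to compound 2, where both ends were limits. With no readable step in this assay, no direction can be drawn; the expectation is that compound 4 also remains at a limit in this assay.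

The estimate for compound 4 in this assay is 40000 nM, with a range from 15000 nM to 100000 nM. The expected step from compound 2 to compound 4 is a step that the limit leaves unreadable from compound 2 to compound 4, most likely unreadable again because of the limits in the limit of > 32300 nM in this assay, at which 1 of the 3 values shown sits.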

Compound 4, half-maximal cytotoxic concentration: > 40600 nM
Compound 4: a limit, no number; the forecaster's own chance of this, stated with the estimate: 85%; middle value at least 1.0-fold (0.00 log units) from the limit.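

In this assay compound 4 gives > 40600 nM, which is a limit of the assay. With limits at both ends, no step can be read from compound 1 or compound 2 to compound 4. The compounds shown leave open whether methyl, pyridin-3-yl or any other group compared here shifts the half-maximal cytotoxic concentration at all.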